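The compounds below may be only part of what the source reports. "The series", "measured", "known", "first", "only" and "open" are said of these compounds alone.

Measured so far in a physicochemical assay for solubility, read by HPLC, in phosphate buffer, at pH 6.5 (a lower number here means a less soluble compound, a higher number a more soluble compound), for this series
- compound 1 `COC(=O)C1=C(C)NC(c2nccs2)=NC1(C)c1ccc(OC)cc1` gives 106 ug/mL
- compound 2 `COC(=O)C1=C(C)NC(c2nccs2)=NC1(C)c1ccc(C#N)cc1` gives 87 ug/mL
- compound 3 `COC(=O)C1=C(CN2CCOCC2=O)NC(c2nccs2)=NC1(C)c1ccc(F)cc1` gives 440 ug/mL

In this assay compound 3 stands highest of the three at 440 ug/mL and lies beyond the scatter from both compound 1 and compound 2. Compound 3 also differs from those two in more than one place, so their values do not isolate the effect of any single group.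

The next compound is compound 4 `COC(=O)C1=C(Cn2ccnc2)NC(c2nccs2)=NC1(C)c1ccc(F)cc1`, which carries 1H-imidazol-1-yl in place of 3-oxomorpholin-4-yl on a saturated chain carbon bound to a double-bonded ring carbon. Among the measured compounds shown here, the only measured single-place step is a 1.2-fold lower number from compound 1 to compound 2 (0.09 log units; within the scatter), and it concerns a different change, cyano in place of methoxy on an aromatic carbon. It bears on this swap only weakly, as a sign that one single-group change in the series stayed small. For the measured compounds named here, no measured step covers the group being replaced.

The estimate therefore starts from compound 3 at 440 ug/mL and leans modestly downward, with no step beyond the scatter firmly expected. The expected change is a 1.8-fold lower number from compound 3 to compound 4 (0.25 log units; within the scatter), and this remains uncertain in both size and direction. For compound 4 the estimated value is 250 ug/mL, with an expected range of 80 ug/mL to 700 ug/mL.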

Compound 4, solubility: 338 ug/mL
Compound 4: the middle estimate sits 1.4-fold (0.13 log units) below what was measured; the range from low to high includes it.
By their numbers in this assay, from the lowest: compounds 2 and 1 (each within the scatter of the next); then compounds 4 and 3 (each within the scatter of the next).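

In this assay, the swap at the saturated chain carbon bound to a double-bonded ring carbon gives a 1.3-fold lower number from compound 3 to compound 4 (0.11 log units; within the scatter), so compound 3 and compound 4 cannot be told apart at this position. Among the compounds shown here, the only earlier single-place step concerned an aromatic carbon; this one shows that, at a different place, a one-ring group of 7 heavy atoms with a six-membered non-aromatic ring can give way to one of 5 heavy atoms with a five-membered aromatic ring without a read-out change beyond the scatter, with both groups counted at 0 hydrogen-bond donors, 2 hydrogen-bond acceptors and no net charge. No independent measurement is available to account for this result or to tie either group to the read-out.

Still open is whether a carboxylic acid or an open-chain amine on this same carbon would stay within the scatter of compound 3 and compound 4, as both groups shown here are uncharged rings. Also open, as far as these compounds go, is what either ring contributes relative to the plain methyl of compound 1 and compound 2; those two differ from compound 3 and compound 4 in more than one place.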